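This account rests on a few compounds, and the source may have more. Where it says the series, first, only, none or still open, it means among the compounds named here.

Compound 1, `COc1cccc(Nc2n[nH]c(-c3cccnc3Nc3cc(OC)cc(OC)c3)n2)c1`: 90 nM
Compound 2, `COc1cc(Nc2ncccc2-c2nc(Nc3cc(OC)ccc3OC)n[nH]2)cc(OC)c1`: > 10000 nM
Compound 3, `COc1cccc(Nc2n[nH]c(-c3cccnc3Oc3cc(OC)cc(OC)c3)n2)c1`: 21 nM

In a functional assay on A-431 cells (Homo sapiens) (a higher number here means that more compound is needed for the effect, a lower number that less compound is needed), compound 1 gives 90 nM. Compound 2 gives only > 10000 nM, which is a limit of the assay and not a number. The change from compound 1 to compound 2 is methoxy in place of hydrogen on an aromatic carbon and it produced an at least 110-fold higher number from compound 1 to compound 2 (2.04 log units; beyond the scatter). Because of the limit of > 10000 nM in this assay, at which 1 of the 3 values shown sits, the true size of that step is not known, only its floor.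

Compound 3 gives 21 nM, the lowest of the two numbers shown, and its step from compound 1 lies beyond the scatter. How the core of compound 3 differs from that of compound 1 is not broken down here.

Compound 4, `COc1cc(Nc2n[nH]c(-c3cccnc3Oc3cc(OC)cc(OC)c3)n2)cc(OC)c1`, is not yet measured. It differs from compound 3 by methoxy in place of hydrogen on an aromatic carbon. For the measured compounds named here, this is the same kind of change as the one from compound 1 to compound 2, but not the same: there the entering methoxy sat ortho to a large group and para to a methoxy group, here it sits meta to a large group and meta to a methoxy group, so the pair reads 3-methoxyphenyl to 3,5-dimethoxyphenyl rather than 3-methoxyphenyl to 2,5-dimethoxyphenyl. In this assay compound 4 is therefore expected to lose some ground against compound 3, but by a smaller step than an at least 110-fold higher number from compound 1 to compound 2 (2.04 log units; beyond the scatter), the estimated step being a 3.3-fold higher number from compound 3 to compound 4 (0.52 log units; beyond the scatter). Compound 4 is estimated at 70 nM, with a range from 15 nM to 500 nM.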

Compound 4, half-maximal effective concentration: 23 nM
Compound 4: middle estimate off by 3.0-fold (0.48 log units), on the high side; the range from low to high includes it.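

In this assay, methoxy in place of hydrogen on the aromatic carbon gave a 1.1-fold higher number from compound 3 to compound 4 (0.04 log units; within the scatter), so on the core of compound 3 the change from 3-methoxyphenyl to 3,5-dimethoxyphenyl leaves the number where it was. The addition of a methoxy group therefore does not carry over as one fixed step between the two cores shown: the same change on two cores in this assay, an at least 110-fold higher number (2.04 log units; beyond the scatter) from compound 1 to compound 2 and a 1.1-fold higher number (0.04 log units; within the scatter) from compound 3 to compound 4, at least 100-fold (2.00 log units) apart, beyond the scatter of two such steps This does not show whether the core or the place of the methoxy sets that gap, as the earlier step reads 3-methoxyphenyl to 2,5-dimethoxyphenyl and the new one 3-methoxyphenyl to 3,5-dimethoxyphenyl, and the earlier step is known only as a floor, with compound 2 standing at a limit of the assay: the limit of > 10000 nM in this assay, at which 1 of the 4 values shown sits.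

The compounds shown leave open how the 2,5-dimethoxyphenyl group reads on the core of compound 3 and how the 3,5-dimethoxyphenyl group reads on the core of compound 1, the two comparisons that would separate the place of the methoxy from the core. They also leave open whether a different group at the same place, such as ethoxy, fluorine or an amine, would match methoxy in this assay.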